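The compounds below may be only part of what the source reports. "The series", "measured", "known", "first", "only" and "open" are said of these compounds alone.

Compound 1 `Nc1ccccc1NC(=O)c1ccc(NC(=S)NCc2cncc(Br)c2)cc1`: 7500 nM in a functional assay on HepG2 cells (Homo sapiens) for cytotoxicity, read by MTT assay, with a stated time of 72 h; a higher number here means a weaker inhibitor, a lower number a stronger inhibitor
Compound 2 `Nc1ccccc1NC(=O)c1ccc(NC(=S)NCc2cccc(F)c2)cc1`: 2900 nM
Compound 3 `Nc1ccccc1NC(=O)c1ccc(NC(=S)NCc2ccccc2F)cc1`: 5400 nM

Among these three numbers compound 3 holds the second highest; the step of a 1.4-fold lower number from compound 1 to compound 3 (0.14 log units; within the scatter) stays within the scatter, and so does a 1.9-fold higher number from compound 2 to compound 3 (0.27 log units; within the scatter), so compound 3 cannot be separated from either neighbour. Compound 4 `Nc1ccccc1NC(=O)c1ccc(NC(=S)NCc2cccnc2)cc1` differs from compound 3 by pyridin-3-yl in place of 2-fluorophenyl on a saturated chain carbon bound to an amide-type nitrogen. For the measured compounds named here, the only measured step that bears on this is a 1.4-fold lower number from compound 1 to compound 3 (0.14 log units; within the scatter), read in reverse, since pyridin-3-yl is 5-bromopyridin-3-yl without the bromine; no measured pair isolates that bromine. The expected step of a 1.2-fold higher number from compound 3 to compound 4 (0.08 log units; within the scatter) is therefore small, leaning toward a higher number, but not beyond the scatter. Compound 4 is estimated at 6500 nM, with a range from 2800 nM to 15000 nM.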

Compound 4, half-maximal inhibitory concentration: 4200 nM
Compound 4: the middle estimate sits 1.5-fold (0.19 log units) above what was measured; the range from low to high includes it.
By their numbers in this assay, from the lowest: compounds 2, 4, 3 and 1 (each within the scatter of the next, the first and the last beyond it).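

In this assay the bromine can now be read alone: a 1.8-fold lower number from compound 1 to compound 4 (0.25 log units; within the scatter), with hydrogen in place of bromo on an aromatic carbon, and this step stays within the scatter. Pyridin-3-yl also cannot be separated from either fluorophenyl group, with a 1.3-fold lower number from compound 3 to compound 4 (0.11 log units; within the scatter) and a 1.4-fold higher number from compound 2 to compound 4 (0.16 log units; within the scatter), so the ring carrying a nitrogen and the rings carrying fluorine read alike at this place. No evidence is available to explain these numbers. From the compounds shown here alone, how an unsubstituted phenyl, a pyridin-4-yl or a longer chain would read at this place stays open.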